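The compounds below may be only part of what the source reports. "The series", "measured", "known", "first", "only" and "open" are said of these compounds alone.

Measured so far in an ADME assay on PC-3 cells (Homo sapiens) for cytotoxicity, read by WST assay, tested at 100 uM; a higher number here means more inhibition at the concentration tested (going by the name of the read-out), a lower number less inhibition:

Compound 1 `O=C(Nc1ccc(Cl)cc1)C1CCCN(C(=O)c2cccc(-c3ccco3)c2)C1` gives 0%.
Compound 2 `O=C(Nc1cccc(OCCc2ccccn2)c1)C1CCCN(C(=O)c2cc(C(F)(F)F)cc(C(F)(F)F)c2)C1` gives 5%.
Compound 3 `CC(C)(C)CC(=O)Nc1cccc(C(=O)N2CCCC(C(=O)Nc3ccc(Cl)cc3)C2)c1` gives 0%.

Compound 2 has the largest of the three numbers, but its gap to compound 1 and to compound 3 lies within the usual scatter of this assay, so all three compounds read as essentially no inhibition at the concentration tested.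

Compound 4 `O=C(Nc1cccc(-c2ccco2)c1)C1CCCN(C(=O)c2cc(C(F)(F)F)cc(C(F)(F)F)c2)C1` is still to be measured. It differs from compound 2 at one place: furan-2-yl in place of 2-(pyridin-2-yl)ethoxy on an aromatic carbon.

Among the compounds with values here, the only measured step is no change at the digits printed from compound 1 to compound 3 (within the scatter), which exchanges a furan-2-yl for a (neopentylcarbonyl)amino group on an aromatic carbon and leaves the read-out unchanged within the scatter. That step touches the same group that enters in compound 4, and it shows no effect on cytotoxicity at this concentration. Within the data shown here, no measured pair covers the 2-(pyridin-2-yl)ethoxy group that leaves. With every number in the series near zero and no step beyond the scatter, no change beyond the scatter is expected for compound 4; the expected step is a number 2 percentage points lower from compound 2 to compound 4 (within the scatter).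

For compound 4 in this assay the estimate is 3%, with a range from -8% to 15%.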

Compound 4, a percentage reported as inhibition, at one concentration (the size of the read-out at that concentration, not a potency): 0%
Beside the measured number, compound 4's estimate is 3 percentage points above it; measured number inside the range.
By their numbers in this assay, from the lowest: compounds 1, 3, 4 and 2 (each within the scatter of the next).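

In this assay, placing furan-2-yl on this aromatic carbon, meta to a large group, in place of 2-(pyridin-2-yl)ethoxy gives a number 5 percentage points lower from compound 2 to compound 4 (within the scatter). This is the first measured pair in which the 2-(pyridin-2-yl)ethoxy group leaves, and the change from 9 heavy atoms to 5, with a six-membered aromatic ring with 1 hetero atom giving way to a five-membered aromatic ring with 1 hetero atom, moves the read-out by no more than the scatter, so the pyridine-bearing group is not shown to matter for this read-out in this pair. Nothing available bears on why the read-out stays where it does.

The compounds shown leave open whether an amine or a carboxylic acid on this aromatic carbon, or a longer chain than 2-(pyridin-2-yl)ethoxy, would carry the read-out beyond the scatter. With each compound in the series within the scatter of the next, they also leave open whether any change at this position can separate compounds in this assay at all.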